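Moving a Fluorine Around the Ring in an Anticonvulsant Series

This account rests on a few compounds, and the source may have more. Where it says the series, first, only, none or still open, it means among the compounds named here.

Compound 1, `CCC(C(=O)N1CCN(c2cccc(OC)c2)CC1)N1C(=O)CCC1=O`, gives 0% in a functional assay on the whole organism (strain Swiss) with Mus musculus as the target, in the maximal electroshock model, with a stated time of 1 h, at a dose of 300 mg/kg by the intraperitoneal route; on this read-out lower numbers stand for a weaker effect and higher numbers for a stronger effect at the one dose given. Compound 2, `CCC(C(=O)N1CCN(c2cccc(F)c2)CC1)N1C(=O)CCC1=O`, gives 75% in this assay. The one measured step, a number 75 percentage points higher from compound 1 to compound 2 (beyond the scatter), is the only change shown so far and makes compound 2 the higher of the two numbers, with compound 1 the nearest and far below it.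

Compound 3, `CCC(C(=O)N1CCN(c2ccc(F)cc2)CC1)N1C(=O)CCC1=O`, has not yet been tested. Compared with compound 2 the change is 4-fluorophenyl in place of 3-fluorophenyl on an amine nitrogen in a ring. This moves the fluorine to another spot on the same aromatic ring rather than swapping one group for another, so the measured step from compound 1 to compound 2 does not speak directly to it. For the measured compounds named here, no measured pair shows what moving the fluorine does, so the expectation leans on compound 2 alone and is wide. The step from compound 2 to compound 3 in this assay is expected to be a number 10 percentage points lower from compound 2 to compound 3 (within the scatter), that is, no change beyond the scatter. Compound 3 is estimated at 65%, within a range from 25% to 95%.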

Compound 3, a percentage reported as activity, at one dose (the size of the read-out at that dose, not a potency): 25%
Beside the measured number, compound 3's estimate is 40 percentage points above it, within the range that was stated.
By their numbers in this assay, from the lowest: compound 1; then compound 3; then compound 2.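

In this assay, the two fluorine compounds have the same atoms joined differently, so this pair isolates the effect of where the fluorine sits on the aromatic ring: 4-fluorophenyl in place of 3-fluorophenyl on the amine nitrogen in the ring gives a number 50 percentage points lower from compound 2 to compound 3 (beyond the scatter), a large drop. The high number of compound 2 therefore cannot be credited to the presence of a fluorine alone, since it depends on where that fluorine stands, yet 4-fluorophenyl in place of 3-methoxyphenyl still gives a number 25 percentage points higher from compound 1 to compound 3 (beyond the scatter), a modest gain that stays beyond the scatter. Nothing on hand explains why moving the fluorine has so large an effect.

The compounds shown leave open whether a chlorine atom, a methyl group or a trifluoromethyl group in the place the fluorine holds in compound 2 would keep a number as high as that of compound 2, and whether a phenyl ring with no group on it would fall closer to compound 1 or to compound 2. Each number also comes from a single dose at a single time, so how the compounds compare at lower doses remains an open question.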